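Compound 1 to compound 4: a swapped amine side group

The source may hold more compounds than are shown below. What is called first, only, known or untested is meant among the compounds shown, and "the series" means these compounds.

Among the compounds with values here, in a functional assay on MV4-11 cells (Homo sapiens) for inhibition, read by luminescence, with a stated time of 72 h (a lower number here means a stronger inhibitor, a higher number a weaker inhibitor), compound 1 `CCN1C(=O)COc2c(CN3CCN(C(C)C)CC3)cc(Nc3ncc(F)c(-c4ccc(F)cc4OC)n3)cc21` gives 149 nM as the highest of the three numbers so far, which makes it the weakest inhibitor of the set. Compound 2 `CCN1C(=O)COc2c(CN3CCN(C(C)=O)CC3)cc(Nc3ncc(F)c(-c4ccc(F)cc4OC)n3)cc21` gives 17 nM and compound 3 `CCN1C(=O)COc2c(CN3CCN(S(C)(=O)=O)CC3)cc(Nc3ncc(F)c(-c4ccc(F)cc4OC)n3)cc21` gives 15 nM in the same test. The acetyl change is an 8.8-fold lower number from compound 1 to compound 2 (0.94 log units; beyond the scatter) and the methylsulfonyl change is a 9.9-fold lower number from compound 1 to compound 3 (1.00 log units; beyond the scatter) while a 1.1-fold lower number from compound 2 to compound 3 (0.05 log units; within the scatter) separates the two.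

Compound 4 `CCN1C(=O)COc2c(CN3CCC(N(C)C)C3)cc(Nc3ncc(F)c(-c4ccc(F)cc4OC)n3)cc21` has not yet been measured. It carries 3-(dimethylamino)pyrrolidin-1-yl in place of 4-isopropylpiperazin-1-yl on a saturated chain carbon bound to an aromatic carbon. Both measured steps bear on this only indirectly, as they exchange the isopropyl group and leave the six-membered ring in place. Within the data shown here, no measured compound holds the entering group. Compound 4 carries neither acetyl nor methylsulfonyl, so the large drops are not expected to carry over, and the expectation stays near compound 1 at 149 nM in this assay as the closest reference.

The expected move is a 1.7-fold lower number from compound 1 to compound 4 (0.22 log units; within the scatter) and so only a small one toward lower numbers. Compound 4 is estimated at 90 nM (range 30 nM to 250 nM).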

Compound 4, half-maximal inhibitory concentration: 124 nM
For compound 4 the middle estimate is 1.4-fold (0.14 log units) below the measured one; the measured number falls inside the stated range.
By their numbers in this assay, from the lowest: compounds 3 and 2 (each within the scatter of the next); then compounds 4 and 1 (each within the scatter of the next).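

In this assay, within the data shown here, the earlier compounds changed only the group on the ring nitrogen, whereas compound 4 replaces the whole 4-isopropylpiperazin-1-yl on a saturated chain carbon bound to an aromatic carbon, and this larger change gives a 1.2-fold lower number from compound 1 to compound 4 (0.08 log units; within the scatter), so the six-membered ring with its two hetero atoms can give way to 3-(dimethylamino)pyrrolidin-1-yl without a change that stands out from the scatter. The new amine does not match the acylated or sulfonylated piperazines, as shown by a 7.3-fold higher number from compound 2 to compound 4 (0.86 log units; beyond the scatter) and by an 8.3-fold higher number from compound 3 to compound 4 (0.92 log units; beyond the scatter), which leaves compound 4 with compound 1 and apart from compound 2 and compound 3 among these four. No measurement available here accounts for this grouping.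

Compound 4 changes ring size, hetero atom count and the attachment of the second nitrogen together, so the contribution of each remains unresolved. As far as these compounds go, it also remains open how an acetyl or methylsulfonyl group on the exocyclic amine of a pyrrolidine, or a morpholin-4-yl or unsubstituted piperazin-1-yl group at this place, would read in this assay.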